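Inverting one stereocentre in a series at its limit

This account rests on a few compounds, and the source may have more. Where it says the series, first, only, none or still open, it means among the compounds named here.

Compound 1 `CC(=O)[C@H]1[C@@H](OC=O)CCC2=C[C@@H](O)C[C@H](C)[C@]21C` and compound 2 `CC(=O)[C@H]1[C@@H](O)CCC2=C[C@H](O)C[C@H](C)[C@]21C` have both been read in a functional assay on P388 cells (Mus musculus) for cytotoxicity; on this read-out higher numbers stand for an effect only at larger amounts of compound and lower numbers for an effect already at smaller amounts. Compound 1 gives > 5 ug/mL, which is a limit of the assay. Compound 2 gives > 5 ug/mL, which is likewise a limit and not a number. For the measured compounds named here, the series so far therefore rests on one reading: the limit of > 5 ug/mL in this assay, at which 2 of the 2 values shown sit. Compound 3 `CC(=O)[C@H]1[C@@H](O)CCC2=C[C@@H](O)C[C@H](C)[C@]21C` is reached from compound 2 with the two compounds have the same atoms and bonds and differ only in configuration as drawn: 1 of 5 stereo elements differ; a stereocentre at a saturated ring carbon is drawn R in compound 2 and S in compound 3, at a saturated ring carbon. The expected result is no change beyond the scatter in this assay, an estimated step that the limit leaves unreadable from compound 2 to compound 3. The expected value for compound 3 is 7 ug/mL, within an estimated range of 3 ug/mL to 20 ug/mL.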

Compound 3, concentration for half-maximal effect: > 5 ug/mL
Compound 3 was reported as a limit; the forecaster's own chance of this, stated with the estimate: 80%; the middle value is on the limit's open side.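

For the compounds shown here, no step to compound 3 can be read from compound 1 or compound 2 in this assay; all three readings are limits, not numbers. The compounds shown leave open whether the formyl group or the inverted stereocentre alters the result in this assay.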